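Allyl in Place of Phenyl on the Chain Carbon

A few compounds are considered here, and "the series" means these few. Any claim that something is new, unique, unknown or untested is made for them only; others in the source may bear on it.

Measured so far:
compound 1, `CSC(Cc1cccc(OCC(=O)O)c1)c1nc(-c2ccccc2)c(-c2ccccc2)o1`: 1300 nM in a functional assay for inhibition, with Homo sapiens as the target; a lower number here means a stronger inhibitor, a higher number a weaker inhibitor
compound 2, `O=C(O)COc1cccc(CC(c2ccccc2)c2nc(-c3ccccc3)c(-c3ccccc3)o2)c1`: 23200 nM in this assay

Compound 2 has the highest of the two numbers; its nearest neighbour is compound 1, and the step of an 18-fold higher number from compound 1 to compound 2 (1.25 log units; beyond the scatter) lies beyond the scatter. Compound 3, `C=CCC(Cc1cccc(OCC(=O)O)c1)c1nc(-c2ccccc2)c(-c2ccccc2)o1`, differs from compound 2 in one place: allyl in place of phenyl on a saturated chain carbon bound to an aromatic carbon and a saturated chain carbon. Among the measured compounds shown here, the only measured step that touches this position is an 18-fold higher number from compound 1 to compound 2 (1.25 log units; beyond the scatter), where phenyl on that saturated chain carbon brought a large rise in the number. Allyl, like methylsulfanyl, carries no ring, so the change is expected to move the number back toward that of compound 1, though not necessarily the whole way. For compound 3 the expected step is a 5.8-fold lower number from compound 2 to compound 3 (0.76 log units; beyond the scatter). Compound 3 is therefore estimated at 4000 nM, with a range of 1500 nM to 12000 nM.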

Compound 3, half-maximal inhibitory concentration: 570 nM
Estimate against measurement, compound 3: 7.0-fold (0.85 log units) above; measured number outside the range, below it.
By their numbers in this assay, from the lowest: compound 3; then compound 1; then compound 2.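

With allyl in place of phenyl on this saturated chain carbon, the number in this assay falls sharply, a 41-fold lower number from compound 2 to compound 3 (1.61 log units; beyond the scatter), and compound 3 has the lowest number of the three compounds. The change does more than restore the level of the methylsulfanyl compound: the further step, a 2.3-fold lower number from compound 1 to compound 3 (0.36 log units; beyond the scatter), is modest but lies beyond the scatter. Among these three compounds, the two with no ring on this carbon both have much lower numbers than the phenyl compound, so this position accepts at least two quite different groups without a ring.

From the compounds shown here alone, whether the double bond of allyl contributes remains open, as does how a saturated propyl group, a longer chain or an amine on this carbon would compare with compound 3. Nothing available bears on the reason for these differences.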